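The compounds below may be only part of what the source reports. "The series", "measured", "known", "first", "only" and "open" are said of these compounds alone.

The measured compounds so far:

Compound 1, `N/C(=N\NC(=S)N1CCCCCC1)c1ccccn1`, gives 76.5% in a functional assay on MCF7 cells (Homo sapiens) for cytotoxicity, read by MTT assay, with a stated time of 72 h, tested at 30 uM; a lower number here means less inhibition of growth, a higher number more inhibition of growth at the concentration tested.
Compound 2, `N/C(=N\NC(=S)N1CCSCC1)c1ccccn1`, gives 72.6% in this assay.
Compound 3, `N/C(=N\NC(=S)N1CCSCC1)c1ccc(F)cn1`, gives 58.8% in this assay.

Compound 1 and compound 2 share most of their structure; how their two cores differ is not broken down here. Their values in this assay lie within the scatter of each other, so no order between them can be read from these numbers. Compound 3 is obtained from compound 2 by a single change: fluoro in place of hydrogen on an aromatic carbon. Alongside this change the measurement moved by a number 13.8 percentage points lower from compound 2 to compound 3 (beyond the scatter), a modest shift that is beyond the scatter.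

Compound 4, `N/C(=N\NC(=S)N1CCCCCC1)c1ccc(F)cn1`, is the compound not yet measured. It stands to compound 1 as compound 3 stands to compound 2: fluoro in place of hydrogen on an aromatic carbon. The place of the change is described in the same words for both pairs, so this is the same change, carried out on the core of compound 1 rather than that of compound 2. For the measured compounds named here, there is only one earlier example of it, and there is no information on whether the change behaves alike on the two cores; the step seen from compound 2 to compound 3 is the sole guide. Compound 4 is therefore expected to show a similar drop, a number 13.5 percentage points lower from compound 1 to compound 4 (beyond the scatter), because compound 1 gives 76.5% and the same change earlier brought a number 13.8 percentage points lower from compound 2 to compound 3 (beyond the scatter). Compound 4 is estimated at 63%, most likely between 50% and 76%.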

Compound 4, percent growth inhibition at one concentration: 68.2%
For compound 4 the middle estimate is 5.2 percentage points below the measured one, within the range that was stated.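

In this assay, fluoro in place of hydrogen on an aromatic carbon gave a number 8.3 percentage points lower from compound 1 to compound 4 (within the scatter), so on the core of compound 1 this step alone cannot be told apart from the ordinary spread of repeated measurements. Set beside the earlier example, the two steps do not differ by more than these numbers can resolve: the same change on two cores in this assay, a number 13.8 percentage points lower (beyond the scatter) from compound 2 to compound 3 and a number 8.3 percentage points lower (within the scatter) from compound 1 to compound 4, 5.5 percentage points apart, within the scatter of two such steps. For the compounds shown here, this fits the idea that the change carries over from one core to the other, but it does not prove it, since only two pairs are available, one step lies beyond the scatter and the other within it, and each rests on a single read-out at one concentration in one cell line.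

The compounds shown carry only hydrogen or fluoro at this place on the ring, so it remains open whether a chloro group, a methoxy group or an amine there would behave in the same way, or whether fluoro elsewhere on the ring would. From the compounds shown here alone, it is also open how the same change would fare on a third core, and whether the two steps would look alike in other cell lines or at other concentrations.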